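Cytotoxicity notes: removing the methyl from the aryl-amine nitrogen

The source may report more compounds than this note shows. Statements on the series, on what has been measured and on what is new or still open speak of the compounds shown alone.

The series is followed in an ADME assay on BaF3 cells (Mus musculus) for cytotoxicity; a lower number here means that less compound is needed, a higher number that more compound is needed for the effect. Compound 1 `FC(F)(F)Oc1ccc(Nc2cc(-n3ccnc3)ncn2)cc1` is a ring-substituted analogue of the shared core. In this assay compound 1 gives > 10000 nM, which is a limit of the assay and not a number. Compound 2 `CN(c1ccc(OC(F)(F)F)cc1)c1cc(-c2ccncc2)ncn1` carries a methyl on the nitrogen that joins the aryl group to the core. In this assay compound 2 gives > 10000 nM, again a limit and not a number. For the measured compounds named here, both values therefore sit at the limit of > 10000 nM in this assay, at which 2 of the 2 values shown sit; no step between measured compounds can be given. Compound 3 `FC(F)(F)Oc1ccc(Nc2cc(-c3ccncc3)ncn2)cc1` differs from compound 2 by hydrogen in place of methyl on a nitrogen on an aromatic ring. With both neighbours sitting at the limit, no step beyond the scatter is expected, and the result for compound 3 is most likely also reported as a limit. The step from compound 2 to compound 3 is expected to be about a step that the limit leaves unreadable from compound 2 to compound 3. For compound 3 the estimate is 15000 nM, with a range from 7000 nM to 40000 nM.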

Compound 3, half-maximal effective concentration: > 10000 nM
Compound 3: a limit, no number; the forecaster's own chance of this, stated with the estimate: 85%; the middle value does not contradict the limit.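

In this assay, for the compounds shown here, compound 3 gives > 10000 nM, a limit and not a number, so no step from compound 1 or compound 2 to compound 3 can be read: the limit of > 10000 nM in this assay, at which 3 of the 3 values shown sit. The compounds shown leave open whether hydrogen in place of methyl, or pyridin-4-yl in place of 1H-imidazol-1-yl, changes cytotoxicity at all.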